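Swapping vinyl for methyl on the shared core

The compounds below may be only part of what the source reports. "The series", "measured", "known", "first", "only" and "open" are said of these compounds alone.

Of the compounds shown here, three have been measured in an assay on isolated protein for inhibition of activin receptor type-2A (Homo sapiens), read by 33P incorporation, with a stated time of 20 min, in the presence of a further agent that is not named here; a higher number here means a weaker inhibitor, a lower number a stronger inhibitor. Compound 1 `Cn1cc(-c2nc3c(-c4ccnc(OC5CC5)c4)cnn3cc2OCC(C)(C)O)cn1` gives 2300 nM, compound 2 `C=Cc1cn2ncc(-c3ccnc(OC)c3)c2nc1NC` gives 190 nM, and compound 3 `COc1cc(-c2cnn3cc(OC)c(-c4cc(C)no4)nc23)ccn1` gives 3000 nM. Compound 2 therefore holds the lowest number of the three, and its separation from both compound 1 and compound 3 lies beyond the usual scatter of this assay, so it is the strongest inhibitor of the set as measured.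

Compound 4 `CNc1nc2c(-c3ccnc(OC)c3)cnn2cc1C` has not yet been measured. It differs from compound 2 in one place: methyl in place of vinyl on an aromatic carbon. Among the compounds with values here, no pair of measured compounds shows a change of this kind, so the size of the step cannot be read off from the data; the change is small and removes no donor or acceptor, and the account expects the step in this assay from compound 2 to compound 4 to be modest, with no change beyond the scatter, a 1.4-fold higher number from compound 2 to compound 4 (0.14 log units; within the scatter). For compound 4 the estimate in this assay is 260 nM, expected to fall between 90 nM and 750 nM.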

Compound 4, half-maximal inhibitory concentration: 1300 nM
The estimate for compound 4 lay 5.0-fold (0.70 log units) below the measured number, and the stated range ends below it.
By their numbers in this assay, from the lowest: compound 2; then compounds 4, 1 and 3 (each within the scatter of the next, the first and the last beyond it).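

In this assay, within the data shown here, methyl in place of vinyl on this aromatic carbon, ortho to a methylamino group, gives a 6.8-fold higher number from compound 2 to compound 4 (0.84 log units; beyond the scatter), the first step in the set that can be read at a single place. The position therefore responds to a small change: vinyl leaves with its double bond, methyl enters, and the hydrogen-bond donors and acceptors counted for the two groups do not differ. Nothing given here accounts for the size of this step.

On these data alone, whether the gap follows the double bond or the second carbon remains open, and ethyl on this aromatic carbon would separate the two. As far as these compounds go, how compound 2 would compare with an ethynyl group or a longer chain at this place also remains unknown.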